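The source may report more compounds than this note shows. Statements on the series, on what has been measured and on what is new or still open speak of the compounds shown alone.

Compound 1 `O=C1/C(=C\c2ccccc2)c2c(ncn2COCc2ccccc2)CCN1Cc1ccccc1` is the reference point. In a functional assay on BGC-823 cells (Homo sapiens) for inhibition, read by MTT assay, with a stated time of 72 h (on this read-out lower numbers stand for stronger inhibition and higher numbers for weaker inhibition), compound 1 gives 20400 nM, the second highest of the three numbers measured. Compound 2 `Cc1cccc(CN2CCc3ncn(COCc4ccccc4)c3/C(=C/c3ccccc3)C2=O)c1` gives 14600 nM, and compound 3 `Cc1ccccc1CN1CCc2ncn(COCc3ccccc3)c2/C(=C/c2ccccc2)C1=O` gives 31300 nM. Compound 4 `CC(C)(C)c1ccc(CN2CCc3ncn(COCc4ccccc4)c3/C(=C/c3ccccc3)C2=O)cc1` has not yet been measured; it differs from compound 1 by tert-butyl in place of hydrogen on an aromatic carbon, on an aromatic carbon of a six-membered aromatic ring of carbon only.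

The measured steps that bear on this change are the two in which a methyl entered an aromatic carbon of the same kind: a 1.4-fold lower number from compound 1 to compound 2 (0.15 log units; within the scatter) and a 1.5-fold higher number from compound 1 to compound 3 (0.19 log units; within the scatter). Neither moved the number beyond the scatter of repeated measurements. Within the data shown here, the change to compound 4 brings in a larger group than a methyl, and no measured step covers a tert-butyl, so the expectation rests on the methyl steps alone. On that basis the expected step is a 1.1-fold lower number from compound 1 to compound 4 (0.05 log units; within the scatter), nothing beyond the scatter. The estimate for compound 4 is 18000 nM, expected to fall between 7000 nM and 45000 nM.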

Compound 4, half-maximal inhibitory concentration: 27800 nM
The estimate for compound 4 lay 1.5-fold (0.19 log units) below the measured number, and the stated range covers the measured number.
By their numbers in this assay, from the lowest: compounds 2, 1, 4 and 3 (each within the scatter of the next, the first and the last beyond it).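

In this assay, tert-butyl on this aromatic carbon gives a 1.4-fold higher number from compound 1 to compound 4 (0.13 log units; within the scatter) and so shows that even a group with more carbons than methyl produces no step beyond the scatter here. Compound 4 also stays close to both methyl compounds, with a 1.1-fold lower number from compound 3 to compound 4 (0.05 log units; within the scatter) and a 1.9-fold higher number from compound 2 to compound 4 (0.28 log units; within the scatter) as its steps, even though compound 2 and compound 3 differ from each other beyond the scatter. No measurement at hand explains why this change moves the number so little.

From the compounds shown here alone, all the groups added to this ring so far contain only carbon and hydrogen, so it remains open whether an amine or a carboxylic acid here would produce a step beyond the scatter. Going by these compounds, whether any change at this position could bring the number well below that of compound 1 also remains open.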